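Removing the tert-butyl from compound 2: working notes

The compounds below may be only part of what the source reports. "The series", "measured", "known", "first", "only" and "open" are said of these compounds alone.

In a functional assay on MDA-MB-231 cells (Homo sapiens) for cytotoxicity, read by MTT assay, with a stated time of 72 h (on this read-out lower numbers stand for stronger inhibition and higher numbers for weaker inhibition), compound 1 `CCN(CC)Cc1ccc2nc(NC(=O)N/N=C/c3cn(Cc4ccc(C(C)(C)C)cc4)c4ccccc34)sc2c1` gives 2120 nM and compound 2 `CN(C)Cc1ccc2nc(NC(=O)N/N=C/c3cn(Cc4ccc(C(C)(C)C)cc4)c4ccccc34)sc2c1` gives 2230 nM. Going by the values given here, these are the only two numbers, and they lie within the scatter of each other, so compound 2 stands level with its sole neighbour. Compound 3 `CC1CCN(Cc2ccc3nc(NC(=O)N/N=C4\C(=O)Nc5ccc(F)cc54)sc3c2)CC1` stands as "not determined" (no result reported), so no result is reported for it.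

Compound 4 `CN(C)Cc1ccc2nc(NC(=O)N/N=C/c3cn(Cc4ccccc4)c4ccccc34)sc2c1` departs from compound 2 by hydrogen in place of tert-butyl on an aromatic carbon. Among the compounds with values here, the only measured step, a 1.1-fold higher number from compound 1 to compound 2 (0.02 log units; within the scatter), exchanges diethylamino for dimethylamino and bears only indirectly, as no measured step touches the tert-butyl. As far as these compounds go, the direction therefore stays open. In this assay the expected step, held loosely, is a 1.3-fold higher number from compound 2 to compound 4 (0.13 log units; within the scatter), a modest move toward a higher number. The estimated value for compound 4 is 3000 nM, with an expected range of 900 nM to 10000 nM.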

Compound 4, half-maximal inhibitory concentration: 1340 nM
Compound 4: middle estimate off by 2.2-fold (0.35 log units), on the high side, within the range that was stated.
By their numbers in this assay, from the lowest: compounds 4, 1 and 2 (each within the scatter of the next).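

In this assay, going by these compounds alone, the change from 4-(tert-butyl)benzyl to benzyl gives a 1.7-fold lower number from compound 2 to compound 4 (0.22 log units; within the scatter), the first measured step at this position. In this single pair, then, the tert-butyl and its 4 heavy atoms can give way to hydrogen without a step beyond the scatter. No measurement at hand bears on a cause for this step.

As far as these compounds go, whether a carboxylic acid or a methoxy group at this position would move the number beyond the scatter remains open. So does whether the same exchange reads alike with the diethylamino group of compound 1.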